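Dichlorobenzamide propanoic acids: antiproliferative working notes

The source may report more compounds than this note shows. Statements on the series, on what has been measured and on what is new or still open speak of the compounds shown alone.

Measured so far:
compound 1, `CC(C)(C)c1ccc(C(CC(=O)O)NC(=O)c2c(Cl)cccc2Cl)cc1`: in a functional assay on MDA-MB-231 cells (Homo sapiens) for antiproliferative activity, read by MTT assay, with a stated time of 24 h (a higher number here means a weaker inhibitor, a lower number a stronger inhibitor), compound 1 reaches only a limit of the assay, > 100000 nM.
compound 2, `CC(C)(C)c1ccc(C(CC(=O)O)NC(=O)c2ccc(Cl)cc2Cl)cc1`: in this assay compound 2 gives 67800 nM.
compound 3, `O=C(O)CC(NC(=O)c1c(Cl)cccc1Cl)c1ccc(Cl)cc1Cl`: in this assay compound 3 reaches only a limit of the assay, > 100000 nM.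

Among the compounds with values here, the one measured step is an at least 1.4-fold lower number from compound 1 to compound 2 (0.16 log units; that floor lies within the scatter); the change is 2,4-dichlorophenyl in place of 2,6-dichlorophenyl on a carbonyl carbon. Its floor rests on (the limit of > 100000 nM in this assay, at which 2 of the 3 values shown sit), which leaves the true size of the step open. Compound 3 carries a different core; the difference between the core of compound 1 and the core of compound 3 is not broken down here. Compound 4, `O=C(O)CC(NC(=O)c1ccc(Cl)cc1Cl)c1ccc(Cl)cc1Cl`, is not yet measured in this assay. It stands to compound 3 as compound 2 stands to compound 1: 2,4-dichlorophenyl in place of 2,6-dichlorophenyl on a carbonyl carbon. The two place descriptions match word for word, so this is the same change.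

Expectation: compound 3 sits at a limit. Any step to compound 4 can only be read downward from that floor. Since the same change gave an at least 1.4-fold lower number from compound 1 to compound 2 (0.16 log units; that floor lies within the scatter), the expected step is a number no higher from compound 3 to compound 4 (the limit leaves the size open), with a limit again about as likely as a number. Compound 4 is expected near 100000 nM, between 40000 nM and 250000 nM.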

Compound 4, half-maximal inhibitory concentration: 49200 nM
Estimate against measurement, compound 4: 2.0-fold (0.31 log units) above; low and high end bracket the measured number.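

In this assay, 2,4-dichlorophenyl in place of 2,6-dichlorophenyl on a carbonyl carbon gives an at least 2.0-fold lower number from compound 3 to compound 4 (0.30 log units; that floor lies within the scatter). Set beside the earlier step, the change points the same way on both cores, with a measured number replacing a limit each time: the same change on two cores in this assay, an at least 1.4-fold lower number (0.16 log units; that floor lies within the scatter) from compound 1 to compound 2 and an at least 2.0-fold lower number (0.30 log units; that floor lies within the scatter) from compound 3 to compound 4; the limit leaves it open whether they differ. The true size of neither step can be read, neither floor goes beyond the scatter, and two cores make no rule for the series, so a shared direction is all that carries over: the limit of > 100000 nM in this assay, at which 2 of the 4 values shown sit.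

The compounds shown leave open how a single chlorine, a methoxy group or a trifluoromethyl group would read in place of the dichlorophenyl chlorines on the group attached to the carbonyl carbon. Also open, from the compounds shown here alone, is whether a methyl ester or a primary amide in place of the carboxylic acid would give numbers rather than limits in this assay, on either the core of compound 1 or the core of compound 3.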